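This account rests on a few compounds, and the source may have more. Where it says the series, first, only, none or still open, it means among the compounds named here.

Compound 1 `C=C[C@@](C)(/C=C/c1ccc(OC(=O)CCC)cc1)CCC=C(C)C`: 38%
Compound 2 `C=C[C@@](C)(/C=C/c1ccc(OC(=O)CCCCCCC)cc1)CCC=C(C)C`: 22%

Going by the values given here, in a functional assay on PC-3 cells (Homo sapiens) for inhibition, with a stated time of 48 h, tested at 50 uM (a higher number here means more inhibition of growth at the concentration tested, a lower number less inhibition of growth), compound 2 gives 22%, the lower of the two numbers measured so far, and compound 1 gives 38%. Compound 3 `C=C[C@@](C)(/C=C/c1ccc(OC(=O)CCCCCCCCC)cc1)CCC=C(C)C` departs from compound 2 by ethyl in place of hydrogen on a saturated chain carbon, seven bonds along the chain from a carbonyl carbon. Among the compounds with values here, only one measured step bears on this change. It is a number 16 percentage points lower from compound 1 to compound 2 (beyond the scatter), a modest fall for butyl in place of hydrogen on a saturated chain carbon, three bonds along the chain from a carbonyl carbon. Ethyl is the smaller addition, so a smaller fall in the same direction is expected, and it may not clear the scatter. The expected change is a number 7 percentage points lower from compound 2 to compound 3 (within the scatter). For compound 3 the estimated value is 15%, within an expected range of 4% to 27%.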

Compound 3, percent growth inhibition at one concentration: 50%
For compound 3 the middle estimate is 35 percentage points below the measured one, and the stated range ends below it.
By their numbers in this assay, from the lowest: compound 2; then compound 1; then compound 3.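

In this assay the chain at this position proved not to act in one direction: ethyl in place of hydrogen, seven bonds along the chain from a carbonyl carbon, gave a number 28 percentage points higher from compound 2 to compound 3 (beyond the scatter) and so reversed the earlier fall. Hexyl in place of hydrogen, three bonds along the chain from a carbonyl carbon, gave a number 12 percentage points higher from compound 1 to compound 3 (beyond the scatter) and so placed the longest chain of the three above the shortest, while the chain of middling length in compound 2 sits lowest. No measurement offered here accounts for this reversal.

On these data alone, whether a longer chain would extend the rise or turn it back remains open. So does the effect of ending the chain in a carboxylic acid or an amine.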